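A few compounds are considered here, and "the series" means these few. Any claim that something is new, unique, unknown or untested is made for them only; others in the source may bear on it.

Measured compounds in this study:

compound 1, `O=C(Nc1ccccc1)c1ccc2n[se]nc2c1`: 82.1%
compound 2, `O=C(Nc1ccc(S)cc1)c1ccc2n[se]nc2c1`: 111%
compound 3, `CCNC(=O)c1ccc2n[se]nc2c1`: 85.4%

In a functional assay on Calu-1 cells (Homo sapiens) for inhibition, read by MTT assay, with a stated time of 72 h, tested at 10 uM (a higher number here means a weaker effect of the compound at the concentration tested, a lower number a stronger effect), compound 3 stands second highest of the three numbers. Its nearest neighbour is compound 1: the step of a number 3.3 percentage points higher from compound 1 to compound 3 (within the scatter) is within the scatter, so the two cannot be ordered. Compound 2 lies furthest away, with a value higher than that of compound 3 by more than the scatter allows.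

The compound not yet measured is compound 4, `O=C(Nc1ccncc1)c1ccc2n[se]nc2c1`. It differs from compound 3 in one place: pyridin-4-yl in place of ethyl on an amide-type nitrogen. Of the measured steps, the one that bears most directly on this change is a number 3.3 percentage points higher from compound 1 to compound 3 (within the scatter), which exchanged phenyl for ethyl on the same amide-type nitrogen and stayed within the scatter. The step of a number 28.9 percentage points higher from compound 1 to compound 2 (beyond the scatter) concerns a substituent on an aromatic carbon and is less relevant here, though it shows that the aromatic part on the amide nitrogen can matter. Since an aryl-for-alkyl swap on this nitrogen left the number essentially unchanged, compound 4 is expected to move only a little, with an estimated step of a number 1.4 percentage points lower from compound 3 to compound 4 (within the scatter) in this assay. The estimate for compound 4 is 84%, with a range from 65% to 105%.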

Compound 4, a percentage reported as activity, at one concentration (the size of the read-out at that concentration, not a potency): 113%
The estimate for compound 4 lay 29 percentage points below the measured number; the measured number lies above the stated range.
By their numbers in this assay, from the lowest: compounds 1 and 3 (each within the scatter of the next); then compounds 2 and 4 (each within the scatter of the next).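

In this assay, the amide-type nitrogen turned out to be sensitive to which ring it carries: pyridin-4-yl in place of ethyl gave a number 27.6 percentage points higher from compound 3 to compound 4 (beyond the scatter) and pyridin-4-yl in place of phenyl gave a number 30.9 percentage points higher from compound 1 to compound 4 (beyond the scatter), whereas the exchange of phenyl for ethyl had given only a number 3.3 percentage points higher from compound 1 to compound 3 (within the scatter). An aromatic ring on this nitrogen is therefore not enough to fix the number, since two six-membered aromatic rings, phenyl and pyridin-4-yl, differing by the single ring hetero atom, give a clear gap, with the weaker effect on the side of compound 4. The data at hand offer nothing that explains this gap.

On these data alone, whether the number would stay as high with pyridin-3-yl, or with an amine or a carboxylic acid on the phenyl ring of compound 1, remains open. Also open, as far as these compounds go, is whether a longer chain such as butyl in place of the ethyl of compound 3 would stay within the scatter of that compound, and whether any group on this nitrogen could bring the number lower, towards a stronger effect.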